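A few compounds are considered here, and "the series" means these few. Any claim that something is new, unique, unknown or untested is made for them only; others in the source may bear on it.

Compound 1 `C/C=C/C=C/C(=O)N(Cc1ccc(OC)c(O)c1)c1cc(OC)c(OC)c(OC)c1` is the most potent of the three compounds measured here: in a functional assay on KYSE-450 cells (Homo sapiens) for inhibition, read by MTT assay, with a stated time of 48 h (a lower number here means a stronger inhibitor, a higher number a weaker inhibitor), compound 1 gives 180 nM. The two other measured compounds are far weaker. Compound 2 `COc1ccc(N(Cc2cc(OC)c(OC)c(OC)c2)C(=O)CCl)cc1O` gives 29800 nM in this assay, and compound 3 `C/C=C/C(=O)N(Cc1ccc(OC)c(OC)c1)c1cc(OC)c(OC)c(OC)c1` gives 39100 nM. Compound 4 `COc1ccc(CN(C(=O)CO)c2cc(OC)c(OC)c(OC)c2)cc1O` is not yet measured. It differs from compound 1 in one place: hydroxymethyl in place of penta-1,3-dien-1-yl on a carbonyl carbon. For the measured compounds named here, neither compound 2 nor compound 3 is a single step from compound 1, so those two values show only that other amide groups on this core sit well above compound 1. Compound 4 is expected to lose much of the potency of compound 1, a step of an 83-fold higher number from compound 1 to compound 4 (1.92 log units; beyond the scatter) in this assay. The estimate for compound 4 is 15000 nM, within 3000 nM to 60000 nM.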

Compound 4, half-maximal inhibitory concentration: 370 nM
Compound 4: the middle estimate sits 41-fold (1.61 log units) above what was measured; measured number outside the range, below it.
By their numbers in this assay, from the lowest: compound 1; then compound 4; then compounds 2 and 3 (each within the scatter of the next).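

In this assay, replacing penta-1,3-dien-1-yl with hydroxymethyl on the carbonyl carbon gives a 2.1-fold higher number from compound 1 to compound 4 (0.31 log units; beyond the scatter), a modest loss. For the compounds shown here, this is the first single change read at this position, and it shows that the diene chain is not needed for most of the potency: a group with fewer heavy atoms and no double bonds stays close to compound 1. Nothing at hand explains this small step.

The compounds shown leave open how a methyl group, an aminomethyl group or a longer saturated chain on this carbonyl carbon would compare with hydroxymethyl.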